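The source may report more compounds than this note shows. Statements on the series, on what has been measured and on what is new or still open speak of the compounds shown alone.

Measured compounds:
compound 1, `O=C(NCc1ccc(S(=O)(=O)c2ccccc2)cc1)N1Cc2ccncc2C1`, which in an ADME assay on microsomes from liver (Homo sapiens) for pharmacokinetics, read by LC-MS, with a stated time of 60 min, tested at 1 uM (a lower number here means slower removal, a higher number faster removal of the compound), gives 7.5 mL/min/kg;
compound 2, `O=C(NCc1ccc(S(=O)(=O)c2cc(F)cc(F)c2)cc1)N1Cc2ccncc2C1`, which gives 8 mL/min/kg;
compound 3, `O=C(NCc1ccc(S(=O)(=O)C2CCCOC2)cc1)N1Cc2ccncc2C1`, which gives 7 mL/min/kg.

Compound 3 holds the lowest of the three numbers, though its gaps to compound 1 and to compound 2 are within the scatter. Compound 4, `O=C(NCc1ccc(S(=O)(=O)N2CCC[C@H](O)C2)cc1)N1Cc2ccncc2C1`, differs from compound 3 only at the sulfonyl sulfur: 3-hydroxypiperidin-1-yl in place of oxan-3-yl on a sulfonyl sulfur. Going by the values given here, the steps that bear on this change are the earlier exchanges at the same sulfonyl sulfur, a 1.1-fold lower number from compound 1 to compound 3 (0.03 log units; within the scatter) and a 1.1-fold lower number from compound 2 to compound 3 (0.06 log units; within the scatter), both within the scatter, as was a 1.1-fold higher number from compound 1 to compound 2 (0.03 log units; within the scatter). The three groups tried at that position gave no step beyond the scatter, and none beyond it is expected here. Compound 4 is therefore expected at 7 mL/min/kg, between 4 mL/min/kg and 12 mL/min/kg, an expected step of no change at the digits printed from compound 3 to compound 4 (within the scatter).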

Compound 4, clearance: 8 mL/min/kg
The estimate for compound 4 lay 1.1-fold (0.06 log units) below the measured number; measured number inside the range.
By their numbers in this assay, from the lowest: compounds 3, 1, 2 and 4 (each within the scatter of the next).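

On a sulfonyl sulfur, 3-hydroxypiperidin-1-yl brings a ring nitrogen, a hydrogen-bond donor and a defined stereocentre, none of which the earlier groups carried, yet in this assay the exchange for oxan-3-yl stays small (a 1.1-fold higher number from compound 3 to compound 4 (0.06 log units; within the scatter)). The exchanges for the aromatic groups read alike (no change at the digits printed from compound 2 to compound 4 (within the scatter); a 1.1-fold higher number from compound 1 to compound 4 (0.03 log units; within the scatter)), so all four groups at this position now lie within the scatter of one another. No measurement shown here accounts for this. From the compounds shown here alone, whether a carboxylic acid or an amine in place of the hydroxy of 3-hydroxypiperidin-1-yl would move the number beyond the scatter remains open. Going by these compounds, the opposite configuration at the stereocentre also remains open.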